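Compound 2: methyl in place of hydroxy

The compounds below may be only part of what the source reports. "The series", "measured", "known", "first", "only" and "open" are said of these compounds alone.

Going by the values given here, in an ADME assay on microsomes from liver (Rattus norvegicus) for metabolic stability (on this read-out higher numbers stand for a longer-lived compound and lower numbers for a shorter-lived compound), compound 2 `CC(O)COc1ccc2c(Oc3ccc(Nc4nccc5[nH]cc(-c6ccc(F)cc6)c(=O)c45)cc3F)ccnc2c1` gives 1.42 h, the lowest of the numbers so far. Compound 1 `CC(C)(O)COc1ccc2c(Oc3ccc(Nc4nccc5[nH]cc(-c6ccc(F)cc6)c(=O)c45)cc3F)ccnc2c1` gives 4.14 h. Compound 3 `CC(C)COc1ccc2c(Oc3ccc(Nc4nccc5[nH]cc(-c6ccc(F)cc6)c(=O)c45)cc3F)ccnc2c1` has methyl in place of hydroxy on a saturated chain carbon bound to two saturated chain carbons. Among the compounds with values here, the one measured step, a 2.9-fold lower number from compound 1 to compound 2 (0.46 log units; beyond the scatter), is modest and keeps the hydroxy, so it bears only indirectly. Within the data shown here, no measured pair shows the loss of the hydroxy. The expected result is a 1.2-fold lower number from compound 2 to compound 3 (0.07 log units; within the scatter), a slight fall not beyond the scatter. For compound 3 the estimate is 1.2 h, with an expected range of 0.45 h to 3.2 h.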

Compound 3, half-life: 1.5 h
The estimate for compound 3 lay 1.3-fold (0.10 log units) below the measured number, within the range that was stated.
By their numbers in this assay, from the lowest: compounds 2 and 3 (each within the scatter of the next); then compound 1.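

Placing methyl for hydroxy on the 2-hydroxypropoxy chain gives a 1.1-fold higher number from compound 2 to compound 3 (0.02 log units; within the scatter) in this assay and so no readable difference between 2-hydroxypropoxy and isobutoxy at this position. Going by these compounds alone, removing the hydroxy from the chain of compound 1 gives a 2.8-fold lower number from compound 1 to compound 3 (0.44 log units; beyond the scatter) and is the first measured loss of that group beyond the scatter, so the outcome of losing it differs between these two chains. Nothing measured here explains that difference. As far as these compounds go, it remains open how an amine or a carboxylic acid would compare with the hydroxy on this chain. From the compounds shown here alone, a longer chain also remains open.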